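The compounds below may be only part of what the source reports. "The series", "measured", "known", "first", "only" and "open" are said of these compounds alone.

Measured so far in a functional assay on Molt4/C8 cells (Homo sapiens) for cytotoxicity; a lower number here means a stronger inhibitor, a higher number a weaker inhibitor:
compound 1 `O=C(/C=C/C(=O)N1C/C(=C\c2ccc([N+](=O)[O-])cc2)C(=O)/C(=C/c2ccc([N+](=O)[O-])cc2)C1)Nc1ccc(Cl)cc1` gives 1200 nM;
compound 2 `O=C(/C=C/C(=O)N1C/C(=C\c2ccccc2)C(=O)/C(=C/c2ccccc2)C1)Nc1ccccc1` gives 520 nM;
compound 3 `O=C(/C=C/C(=O)N1C/C(=C\c2ccc([N+](=O)[O-])cc2)C(=O)/C(=C/c2ccc([N+](=O)[O-])cc2)C1)Nc1ccccc1` gives 360 nM.

Compound 4 `O=C(/C=C/C(=O)N1C/C(=C\c2ccccc2)C(=O)/C(=C/c2ccccc2)C1)Nc1ccc(Cl)cc1` is not yet measured. Its difference from compound 2 is chloro in place of hydrogen on an aromatic carbon. The same change has been measured once already, from compound 3 to compound 1, where it reads chloro in place of hydrogen on an aromatic carbon and made a 3.3-fold higher number from compound 3 to compound 1 (0.52 log units; beyond the scatter). The place is identical in both pairs, so this is the same change, not merely the same kind. The difference between the core of compound 2 and the core of compound 3 is not broken down here; their values lie within the scatter of each other. In this assay, going by the values given here, the step to compound 4 is expected to be of about the earlier size, a 2.9-fold higher number from compound 2 to compound 4 (0.46 log units; beyond the scatter), resting solely on a 3.3-fold higher number from compound 3 to compound 1 (0.52 log units; beyond the scatter) as the one measured instance. Compound 4 is therefore estimated at 1500 nM, expected between 700 nM and 3500 nM.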

Compound 4, half-maximal inhibitory concentration: 1800 nM
Compound 4: middle estimate off by 1.2-fold (0.08 log units), on the low side; low and high end bracket the measured number.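

In this assay, the change from phenylcarbamoyl to (4-chlorophenyl)carbamoyl gives a 3.5-fold higher number from compound 2 to compound 4 (0.54 log units; beyond the scatter), and its size carries over from one core to the other: the same change on two cores in this assay, a 3.3-fold higher number (0.52 log units; beyond the scatter) from compound 3 to compound 1 and a 3.5-fold higher number (0.54 log units; beyond the scatter) from compound 2 to compound 4, 1.0-fold (0.02 log units) apart, within the scatter of two such steps

Going by these compounds alone, the agreement rests on only two pairs, one on the core of compound 2 and one on the core of compound 3. It shows that the step holds on these two cores, but not that it would hold on any other core, and it gives no reason for the step.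

Still open, from the compounds shown here alone, is how a fluoro or a methoxy group would compare with chloro at this place on the ring. Also open, going by these compounds, is what an amine or a carboxylic acid there would do in this assay.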